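A few compounds are considered here, and "the series" means these few. Any claim that something is new, unique, unknown or untested is made for them only; others in the source may bear on it.

Series notes. In an assay on isolated protein for inhibition of phosphodiesterase 1 (Bos taurus), read by cGMP accumulation, in the presence of a further agent that is not named here (a lower number here means a stronger inhibitor, a higher number a weaker inhibitor), compound 3 `CCOC(=O)CCCOc1cc(C2CNC(=O)C2)ccc1OC` gives only a limit, > 1000000 nM. Compound 1 `C=CCOc1cc(C2CNC(=O)C2)ccc1OC` likewise returns a limit, > 1000000 nM. Compound 2 `C=C(C)COc1cc(C2CNC(=O)C2)ccc1OC` also sits at a limit, > 1000000 nM. All three thus stand at the limit of > 1000000 nM in this assay, at which 3 of the 3 values shown sit, so the steps a step that the two limits leave unreadable from compound 1 to compound 2, a step that the two limits leave unreadable from compound 1 to compound 3 and a step that the two limits leave unreadable from compound 2 to compound 3 have no readable size. Compound 4 `COc1ccc(C2CNC(=O)C2)cc1OCCCC(=O)N(C)C1CCCCC1` differs from compound 3 by cyclohexyl(methyl)amino in place of ethoxy on a carbonyl carbon. Among the compounds with values here, none of the measured steps touches the carbonyl carbon in this way, and none is readable, so neither direction nor size can be drawn from them for this assay. The expectation is that compound 4 again returns a limit in this assay, with a number no higher from compound 3 to compound 4 (the limit leaves the size open) not exceeding the scatter, estimated at 1000000 nM within 300000 nM to 3000000 nM.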

Compound 4, half-maximal inhibitory concentration: > 1000000 nM
Compound 4: only a limit was reported (the forecaster's own chance of this, stated with the estimate: 80%); the middle value lies on the limit itself.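

Within the data shown here, compound 3 and compound 4 each give only a limit, so no step between them can be read. In this assay the compounds shown leave open which group on the shared core, if any, would give a number rather than a limit.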